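The source may report more compounds than this note shows. Statements on the series, on what has been measured and on what is new or still open speak of the compounds shown alone.

Measured so far:
- compound 1 `COc1ccc(-n2nc(-c3ccccc3)nc2CNc2ccc(C(=O)NO)cc2)cc1` — 63.4%
- compound 2 `CCc1ccc(-c2nc(CNc3ccc(C(=O)NO)cc3)n(-c3ccccc3)n2)cc1` — 54.6%

In an assay on Sf9 cells for inhibition of protein deacetylase HDAC6 (Homo sapiens), read by fluorescence, with a stated time of 40 min, tested at 100 nM (on this read-out lower numbers stand for less inhibition and higher numbers for more inhibition at the one concentration tested (going by the name of the read-out)), compound 1 gives 63.4%, the higher of the two numbers measured. Compound 2 gives 54.6%, which sits within the usual scatter of the number for compound 1, so the two cannot be ranked. Compound 3 `O=C(NO)c1ccc(NCc2nc(-c3ccccc3)nn2-c2ccc(F)cc2)cc1` differs from compound 1 in one place: fluoro in place of methoxy on an aromatic carbon. Among the compounds with values here, no step between measured compounds covers this change, so the step from a number 5.4 percentage points lower from compound 1 to compound 3 (within the scatter) is estimated to be small and not beyond the scatter, in either direction. Compound 3 is expected to give 58%, within a range of 35% to 78%.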

Compound 3, a percentage reported as inhibition, at one concentration (the size of the read-out at that concentration, not a potency): 67.6%
Compound 3: middle estimate off by 9.6 percentage points, on the low side; the range from low to high includes it.
By their numbers in this assay, from the lowest: compounds 2, 1 and 3 (each within the scatter of the next, the first and the last beyond it).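

In this assay, 4-fluorophenyl in place of 4-methoxyphenyl gives a number 4.2 percentage points higher from compound 1 to compound 3 (within the scatter), so the two groups cannot be ranked at this position, para to a large group. This first one-place comparison shows that fluoro, with one heavy atom, can stand where methoxy, with two, stood without a change beyond the scatter. Nothing measured here bears on why the two read alike. The compounds shown leave open whether an amine, a carboxylic acid or a longer chain such as butoxy would read the same at this position.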